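Morpholine to piperazine on the distal sulfonyl

The compounds below may be only part of what the source reports. "The series", "measured", "known", "first", "only" and "open" are said of these compounds alone.

Compound 1 `CCOC(=O)[C@@H]1CCCN(S(=O)(=O)c2ccc(S(=O)(=O)N3CCOCC3)cc2)C1` gives 23400 nM in a functional assay on BXPC-3 cells (Homo sapiens) for inhibition, read by MTT assay, with a stated time of 7 days (on this read-out higher numbers stand for weaker inhibition and lower numbers for stronger inhibition), the highest number among the three measured. Among the compounds with values here, compound 2 `CCN(CC)C(=O)[C@@H]1CCCN(S(=O)(=O)c2ccc(S(=O)(=O)N(CC)CC)cc2)C1` gives 10500 nM and compound 3 `CCN(CC)S(=O)(=O)c1ccc(S(=O)(=O)N2CCC[C@@H](C(=O)NC3CN(C(=O)NC(C)(C)C)C3)C2)cc1` gives 10100 nM; the one single-point step measured, a 1.0-fold lower number from compound 2 to compound 3 (0.02 log units; within the scatter), sits on a carbonyl carbon rather than on a sulfonyl. Compound 4 `CCOC(=O)[C@@H]1CCCN(S(=O)(=O)c2ccc(S(=O)(=O)N3CCNCC3)cc2)C1` differs from compound 1 by piperazin-1-yl in place of morpholin-4-yl on a sulfonyl sulfur. Within the data shown here, no measured step touches this sulfonyl amine, and compound 1 differs from compound 2 in two places, so those two values show only a gap, not a step. Since a 1.0-fold lower number from compound 2 to compound 3 (0.02 log units; within the scatter) shows an amine exchange leaving the number within the scatter, compound 4 is expected to show a 1.2-fold lower number from compound 1 to compound 4 (0.07 log units; within the scatter), nothing beyond the scatter. Compound 4 is accordingly estimated at 20000 nM, with a range from 8000 nM to 50000 nM.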

Compound 4, half-maximal inhibitory concentration: > 30000 nM
Compound 4 gave a limit, no number; the forecaster's own chance of this, stated with the estimate: 10%; at least 1.5-fold (0.17 log units) between middle value and limit.
By their numbers in this assay, from the lowest: compounds 3 and 2 (each within the scatter of the next); then compound 1. At a limit, above all of these: compound 4.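

The sulfonyl amine now has its first measured step, and in this assay compound 4 gives only a limit, > 30000 nM, not a number. The step, an at least 1.2-fold higher number from compound 1 to compound 4 (0.10 log units; that floor lies within the scatter), shows that piperazin-1-yl in place of morpholin-4-yl on a sulfonyl sulfur brings no stronger inhibition, but whether the loss exceeds the scatter cannot be read. This reading is bounded only by the assay's range: the limit of > 30000 nM in this assay, at which 1 of the 4 values shown sits.

As far as these compounds go, how a piperidin-1-yl or 4-methylpiperazin-1-yl group would read on this sulfonyl sulfur stays open. So does whether the same exchange behaves alike with a carboxylic acid in place of the ethyl ester.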